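A few compounds are considered here, and "the series" means these few. Any claim that something is new, unique, unknown or untested is made for them only; others in the source may bear on it.

Compound 1 `Cc1cccc(C)c1NC(=O)CSc1nnc(-c2ccoc2C)n1Cc1ccco1` gives in a functional assay on CHO cells for antagonist activity at Orexin/Hypocretin receptor type 1 (Homo sapiens), read by FLIPR and calcium flux (on this read-out lower numbers stand for stronger inhibition and higher numbers for weaker inhibition), the value > 15800 nM, which is a limit of the assay and not a number. Compound 2 `Cc1cccc(NC(=O)CSc2nnc(-c3ccoc3C)n2Cc2ccco2)c1C` gives > 15800 nM, again only a limit. Compound 3 `Cc1occc1-c1nnc(SCC(=O)Nc2ccc(F)cc2)n1Cc1ccco1` gives > 15800 nM, also a limit.

All three values sit at the limit of > 15800 nM in this assay, at which 3 of the 3 values shown sit. The steps a step that the two limits leave unreadable from compound 1 to compound 2, a step that the two limits leave unreadable from compound 1 to compound 3 and a step that the two limits leave unreadable from compound 2 to compound 3 therefore cannot be read in size. Compound 4 `COc1ccccc1NC(=O)CSc1nnc(-c2ccoc2C)n1Cc1ccco1` differs from compound 1 by 2-methoxyphenyl in place of 2,6-dimethylphenyl on an amide-type nitrogen. The three measured steps all change the group on the same amide-type nitrogen, and none of them moved any value off the limit, so no readable step bears on this change. Compound 4 is expected to stay at the limit as well, with a step that the limit leaves unreadable from compound 1 to compound 4 as the expected step. The estimated value of compound 4 is 20000 nM, with a range from 8000 nM to 60000 nM.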

Compound 4, inhibition constant: > 15800 nM
Compound 4 was reported as a limit; the forecaster's own chance of this, stated with the estimate: 85%; the middle value is on the limit's open side.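

Compound 4 sits at a limit of the assay, as do compound 1, compound 2 and compound 3, so no step among them can be read in size: the limit of > 15800 nM in this assay, at which 4 of the 4 values shown sit.

The compounds shown leave open whether any group on the amide-type nitrogen would give a readable value in this assay.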